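The compounds below may be only part of what the source reports. "The series", "measured", "known", "first", "only" and "open" are said of these compounds alone.

Working notes on the series. In a functional assay on A549 cells (Homo sapiens) for antiproliferative activity, read by MTT assay, with a stated time of 48 h (a higher number here means a weaker inhibitor, a lower number a stronger inhibitor), three esters of the shared core have been read, and none of the readings is a number. Compound 1 `C/C(=C\CC/C(C)=C/CC[C@@H]1[C@@]2(C)CCC(=O)C(C)(C)[C@H]2CC[C@@]1(C)O)CC/C=C(\C)C(=O)OCc1cn(-c2ccc(F)cc2)nn1` reads > 150000 nM, which is a limit. Compound 2 `C/C(=C\CC/C(C)=C/CC[C@@H]1[C@@]2(C)CCC(=O)C(C)(C)[C@H]2CC[C@@]1(C)O)CC/C=C(\C)C(=O)OCc1cn(-c2ccccc2[N+](=O)[O-])nn1` reads > 150000 nM, also a limit. On these data alone, compound 3 `C/C(=C\CC/C(C)=C/CC[C@@H]1[C@@]2(C)CCC(=O)C(C)(C)[C@H]2CC[C@@]1(C)O)CC/C=C(\C)C(=O)OCc1cn(-c2ccccc2Br)nn1` reads > 150000 nM, again a limit, so its true position is unknown.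

Compound 4 `C/C(=C\CC/C(C)=C/CC[C@@H]1[C@@]2(C)CCC(=O)C(C)(C)[C@H]2CC[C@@]1(C)O)CC/C=C(\C)C(=O)OCc1cn(-c2ccccc2C)nn1` departs from compound 3 at one place: methyl in place of bromo on an aromatic carbon. This puts methyl in place of bromo on an aromatic carbon, ortho to a large group.

The nearest measured change is a step that the two limits leave unreadable from compound 2 to compound 3, where bromo takes the place of nitro on an aromatic carbon. The other two are a step that the two limits leave unreadable from compound 1 to compound 2 and a step that the two limits leave unreadable from compound 1 to compound 3. None of the three has a readable size, so they give no measure of what a swap on this aryl group can do.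

No step beyond the scatter is expected in this assay, in either direction. Compound 4 is expected to end at the same limit, because the limit of > 150000 nM in this assay, at which 3 of the 3 values shown sit, holds for compound 1, compound 2 and compound 3. The estimated change is a step that the limit leaves unreadable from compound 3 to compound 4. The estimate for compound 4 is 200000 nM, with an expected range of 100000 nM to 400000 nM.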

Compound 4, half-maximal inhibitory concentration: > 150000 nM
Compound 4 gave a limit, no number; the forecaster's own chance of this, stated with the estimate: 90%; the middle value does not contradict the limit.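

In this assay compound 4 gives > 150000 nM, which is a limit. Its steps from compound 1, compound 2 and compound 3 cannot be read, as all four compounds end at the same limit: the limit of > 150000 nM in this assay, at which 4 of the 4 values shown sit. The compounds shown leave open how far each lies beyond that limit, and whether swapping the aryl group changes the reading at all.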